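Chloro to trifluoromethyl on the pendant phenyl ring

A few compounds are considered here, and "the series" means these few. Any claim that something is new, unique, unknown or untested is made for them only; others in the source may bear on it.

The series shares one core, carrying a phenyl ring on the fused seven-membered part. Compound 1 `Cc1nn(C)c2c1C(c1ccccc1)=NCCN2` is the unsubstituted parent and in a functional assay on the whole organism for positive allosteric modulation, with Rattus norvegicus as the target (a lower number here means that less compound is needed, a higher number that more compound is needed for the effect), compound 1 gives 2.5 mg/kg. Compound 2 `Cc1nn(C)c2c1C(c1cccc(Cl)c1)=NCCN2` adds a chloro group; in this assay compound 2 gives 0.63 mg/kg, the lowest number among the two values reported, and the step of a 4.0-fold lower number from compound 1 to compound 2 (0.60 log units; beyond the scatter) is modest but beyond the scatter. Compound 3 `Cc1nn(C)c2c1C(c1cccc(Cl)c1)=NCCN2CCN1CCCC1` carries a 2-(pyrrolidin-1-yl)ethyl on the ring nitrogen; its result in this assay is a limit, > 10 mg/kg, rather than a number (the limit of > 10 mg/kg in this assay, at which 1 of the 3 values shown sits), and the step of an at least 15-fold higher number from compound 2 to compound 3 (1.20 log units; beyond the scatter) is large.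

Compound 4 `Cc1nn(C)c2c1C(c1cccc(C(F)(F)F)c1)=NCCN2` is not yet measured. It differs from compound 2 as follows: trifluoromethyl in place of chloro on an aromatic carbon. Within the data shown here, the only measured step at this aromatic carbon is the one from compound 1 to compound 2, which shows that a substituent there is tolerated and helpful; the step from compound 2 to compound 3 concerns the ring nitrogen and does not bear on this change. Among the measured compounds shown here, no measured pair exchanges one substituent for another at that carbon, so for compound 4 a step of no more than the usual scatter is expected, a 1.3-fold higher number from compound 2 to compound 4 (0.10 log units; within the scatter). The estimate for compound 4 in this assay is 0.8 mg/kg, expected to fall between 0.3 mg/kg and 2.5 mg/kg.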

Compound 4, minimum effective dose: 0.63 mg/kg
Compound 4: the middle estimate sits 1.3-fold (0.10 log units) above what was measured; the range from low to high includes it.
By their numbers in this assay, from the lowest: compounds 2 and 4 (each within the scatter of the next); then compound 1. At a limit, above all of these: compound 3.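

In this assay, the exchange of chloro for trifluoromethyl on this aromatic carbon gives no change at the digits printed from compound 2 to compound 4 (within the scatter), so a substituent of 4 heavy atoms stands here as well as one of 1 heavy atom, with no readable difference between them. Measured against hydrogen, trifluoromethyl gives a 4.0-fold lower number from compound 1 to compound 4 (0.60 log units; beyond the scatter), which matches the printed size of the chloro step, a 4.0-fold lower number from compound 1 to compound 2 (0.60 log units; beyond the scatter), so the gain over the unsubstituted parent is no longer tied to chloro alone, although it rests on these two substituents only. Nothing measured for these compounds gives a reason why the two substituents read alike.

Still open, going by these compounds, is whether the same result would hold at this aromatic carbon for an amine, a carboxylic acid or a longer chain, none of which resembles the two substituents seen so far. Also open, on these data alone, is how trifluoromethyl would behave with the 2-(pyrrolidin-1-yl)ethyl on the ring nitrogen, which with chloro in compound 3 gives a limit, > 10 mg/kg, and not a number.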